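The compounds below may be only part of what the source reports. "The series", "measured", "known", "first", "only" and "open" are said of these compounds alone.

Measured in a functional assay on HeLa cells (Homo sapiens) for cytotoxicity, read by sulforhodamine B assay, with a stated time of 48 h; on this read-out lower numbers stand for stronger inhibition and higher numbers for weaker inhibition:
- compound 1 `CCn1cc(-c2nc3ccccc3[nH]2)c(=O)c2cc(F)c(N3CCNCC3)nc21`: 10000 nM
- compound 2 `CCn1cc(-c2nc3ccc([N+](=O)[O-])cc3[nH]2)c(=O)c2cc(F)c(N3CCNC(C)C3)c(F)c21`: 2400 nM
- compound 3 `CCn1cc(-c2nc3ccc([N+](=O)[O-])cc3s2)c(=O)c2cc(F)c(N3CCNC(C)C3)c(F)c21`: 9900 nM

Compound 1 gives 10000 nM and compound 3 gives 9900 nM, two values within the scatter of each other. Compound 2 gives 2400 nM, a lower number than compound 1, and this gap lies beyond the scatter.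

Next in the series is compound 4 `CCn1cc(-c2nc3ccc(N)cc3[nH]2)c(=O)c2cc(F)c(N3CCNCC3)nc21`, which keeps the core of compound 1 and differs in one place: amino in place of hydrogen on an aromatic carbon. In words, this is amino in place of hydrogen on an aromatic carbon.

Within the data shown here, no measured pair isolates this change, so the size of the step can only be judged loosely. Compound 2 and compound 3 also carry a group on the six-membered aromatic ring of carbon only, but both differ from compound 1 elsewhere too. Their values, 2400 nM for compound 2 and 9900 nM for compound 3, give no single direction. A small move toward a lower number is expected, not clearly beyond the scatter, with no change also plausible.

The expected step is a 1.7-fold lower number from compound 1 to compound 4 (0.22 log units; within the scatter). For compound 4 the estimated value is 6000 nM, with an expected range of 1800 nM to 20000 nM.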

Compound 4, half-maximal inhibitory concentration: > 10000 nM
Compound 4: no number, only a limit; the forecaster's own chance of this, stated with the estimate: 25%; middle value at least 1.6-fold (0.22 log units) from the limit.
By their numbers in this assay, from the lowest: compound 2; then compounds 3 and 1 (each within the scatter of the next).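

In this assay compound 4 gives > 10000 nM, which is a limit of the assay and not a number. Among these compounds, this is the first comparison that changes only one place, amino in place of hydrogen on an aromatic carbon of the six-membered aromatic ring of carbon only, and it reads as a number no lower from compound 1 to compound 4 (the limit leaves the size open). On this read-out the change therefore shows no move toward stronger inhibition, though how far the step goes in the other direction cannot be read: the limit of > 10000 nM in this assay, at which 1 of the 4 values shown sits.

On these data alone, compound 2, with its nitro group on a six-membered aromatic ring of carbon only, gives 2400 nM, but it differs from compound 1 in other places too, so whether a group at this position can lower the number remains open. The compounds shown also leave open how a methoxy group, a carboxylic acid or an acetylated amine in place of that hydrogen would read on the core of compound 1.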